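Acetylating the amino group on a thiophene antiproliferative scaffold

The compounds below may be only part of what the source reports. "The series", "measured", "known", "first", "only" and "open" are said of these compounds alone.

Measured compounds:
- compound 1, `CC(C)(C)NC(=O)c1c(N)sc(-c2ccc(Cl)cc2)c1-c1ccc(Cl)cc1`, 15100 nM
- compound 2, `Nc1sc(-c2ccc(Cl)cc2)c(-c2ccc(Cl)cc2)c1C(=O)N1CCCCC1`, 14300 nM

Both compounds were tested in a functional assay on PC-3 cells (Homo sapiens) for inhibition, read by sulforhodamine B assay, with a stated time of 72 h; a higher number here means a weaker inhibitor, a lower number a stronger inhibitor. Going by the values given here, compound 2 gives 14300 nM, the lowest of the two numbers, though its only neighbour is compound 1 with 15100 nM, and the step of a 1.1-fold lower number from compound 1 to compound 2 (0.02 log units; within the scatter) is within the scatter, so the two cannot be told apart.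

Compound 3, `CC(=O)Nc1sc(-c2ccc(Cl)cc2)c(-c2ccc(Cl)cc2)c1C(=O)N1CCCCC1`, has not yet been measured. It differs from compound 2 in one place: acetyl in place of hydrogen on a nitrogen on an aromatic ring. Among the compounds with values here, no measured step touches this position; the only known step, a 1.1-fold lower number from compound 1 to compound 2 (0.02 log units; within the scatter), concerns the group on the carbonyl carbon and says nothing about acetyl in place of hydrogen on the ring nitrogen. With nothing to go on but the shared core, the expectation in this assay is no step beyond the scatter, with a wide range to allow for the unknown.

Compound 3 is therefore expected to give about 14000 nM, with a range of 4000 nM to 50000 nM. The step this implies, a 1.0-fold lower number from compound 2 to compound 3 (0.01 log units; within the scatter), is an estimate only.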

Compound 3, half-maximal inhibitory concentration: 10300 nM
For compound 3 the middle estimate is 1.4-fold (0.13 log units) above the measured one; the measured number falls inside the stated range.
By their numbers in this assay, from the lowest: compounds 3, 2 and 1 (each within the scatter of the next).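

Going by these compounds alone, this is the first look at the nitrogen on the aromatic ring, a position that the earlier step, on the carbonyl carbon, did not touch. In this assay, going from amino to acetamido gives a 1.4-fold lower number from compound 2 to compound 3 (0.14 log units; within the scatter), so this pair cannot be told apart. Putting acetyl, with its 3 heavy atoms and 1 hydrogen-bond acceptor, in place of hydrogen on this nitrogen therefore leaves no readable mark on the number, at least for this one group on this core. No measurement here bears on the reason for this result.

From the compounds shown here alone, whether a different group on this nitrogen, such as a longer chain on the carbonyl in place of the methyl of acetyl, a benzoyl group or a simple methyl group, would give a step beyond the scatter remains open. The compounds shown also leave open what could move this number at all, since neither step shown, at this nitrogen or on the carbonyl carbon, lies beyond the scatter.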